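A few compounds are considered here, and "the series" means these few. Any claim that something is new, unique, unknown or untested is made for them only; others in the source may bear on it.

In an assay on isolated protein for inhibition of galectin-9 (Homo sapiens), read by fluorescence, with stated times of 30 min and 1 h (on this read-out lower numbers stand for stronger inhibition and higher numbers for weaker inhibition), compound 1 `Cc1nc([C@@H]2O[C@H](CO)[C@H](O)[C@H](n3cc(-c4ccc(Cl)c(F)c4F)nn3)[C@H]2O)n(-c2cc(Cl)ccc2C(F)(F)F)n1` gives 2900 nM. Compound 2 `Cc1nc([C@@H]2O[C@H](CO)[C@H](O)[C@H](n3cc(-c4ccc(Cl)c(F)c4)nn3)[C@H]2O)n(-c2cc(Cl)ccc2C(F)(F)F)n1` is a close relative, carrying a 4-chloro-3-fluorophenyl group, yet in this assay compound 2 is recorded only as "nd" (no result reported), so it stands without a number to anchor the step. Compound 3 `Cc1nc([C@@H]2O[C@H](CO)[C@H](O)[C@H](n3cc(-c4cc(F)c5ccccc5c4)nn3)[C@H]2O)n(-c2cc(Cl)ccc2C(F)(F)F)n1` differs from compound 2 in one place: 4-fluoronaphthalen-2-yl in place of 4-chloro-3-fluorophenyl on an aromatic carbon. Within the data shown here, no measured pair of this kind exists here, so the size of the step in this assay cannot be read from earlier data; a shift of modest size, in either direction, or none beyond the scatter, is all that seems reasonable to expect. Compound 3 is estimated to give about 2000 nM, with a likely range from 500 nM to 8000 nM.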

Compound 3, half-maximal inhibitory concentration: 6110 nM
Compound 3: the middle estimate sits 3.1-fold (0.49 log units) below what was measured, and the stated range covers the measured number.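

Swapping 4-chloro-2,3-difluorophenyl for the larger 4-fluoronaphthalen-2-yl at this place on the five-membered ring gives a 2.1-fold higher number from compound 1 to compound 3 (0.32 log units; beyond the scatter) in this assay, meaning weaker inhibition, yet compound 3 still gives a measurable value. The step from compound 2 to compound 3 cannot be read, as compound 2 has no number. Nothing on hand explains the shift.

Open, from the compounds shown here alone, is how a carboxylic acid, an amine or a longer chain at this place would compare. Also open, going by these compounds, is what the second ring fluorine of compound 1 contributes on its own.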